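The compounds below may be only part of what the source reports. "The series", "measured", "known", "first", "only" and "open" are said of these compounds alone.

In a functional assay on A549 cells (Homo sapiens) for inhibition, read by sulforhodamine B assay, with a stated time of 48 h (on this read-out lower numbers stand for stronger inhibition and higher numbers for weaker inhibition), compound 2 (`COc1ccc(C(OCc2ccccc2)c2cccc3ccccc23)c(OC)c1OC`) gives 13500 nM and compound 1 (`COc1ccc(C(O)(Cc2ccc(C)cc2)c2cccc3ccccc23)c(OC)c1OC`) gives 18700 nM with the two values inside the scatter of each other. The move to compound 3 (`COc1ccc(C(c2ccc(O)cc2)c2cccc3ccccc23)c(OC)c1OC`) puts 4-hydroxyphenyl in place of benzyloxy on a saturated chain carbon bound to two aromatic carbons. Within the data shown here, no measured step covers this change, so the expectation is loose: a modest move towards stronger inhibition in this assay with the estimated size a 1.7-fold lower number from compound 2 to compound 3 (0.23 log units; within the scatter) as the working figure. For compound 3 the expected value is 8000 nM (estimated range 2000 nM to 30000 nM).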

Compound 3, half-maximal inhibitory concentration: 16400 nM
Compound 3: the middle estimate sits 2.1-fold (0.31 log units) below what was measured, and the stated range covers the measured number.
By their numbers in this assay, from the lowest: compounds 2, 3 and 1 (each within the scatter of the next).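

In this assay, 4-hydroxyphenyl in place of benzyloxy on a saturated chain carbon bound to two aromatic carbons gives a 1.2-fold higher number from compound 2 to compound 3 (0.08 log units; within the scatter), so this exchange leaves no readable difference, even though the entering group carries a hydrogen-bond donor and the leaving group carries none. No supporting measurement bears on this result.

Open, as far as these compounds go, is whether any group at this carbon can move the number beyond the scatter. An amine, a carboxylic acid or a longer chain ending in phenyl would test this, as would phenyl without its hydroxy group, which would show whether that hydroxy group matters.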